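The source may hold more compounds than are shown below. What is called first, only, known or untested is meant among the compounds shown, and "the series" means these compounds.

Of the compounds shown here, three from one series have been tested in a functional assay on M14 cells (Homo sapiens) for inhibition, read by sulforhodamine B assay, with a stated time of 48 h; a lower number here means a stronger inhibitor of growth, a higher number a weaker inhibitor of growth. Compound 1 `O=C(Nc1cccc(-n2cc(-c3ccncc3)c(-c3ccc(Cl)c(O)c3)n2)c1)Nc1cccc(C(F)(F)F)c1` gives 1400 nM. Compound 3 `O=C(Nc1cccc(-n2cc(-c3ccncc3)c(-c3ccc(Cl)c(O)c3)n2)c1)Nc1cc(C(F)(F)F)cc(C(F)(F)F)c1` gives 607 nM. Compound 2 `COc1cc(-c2nn(-c3cccc(NC(=O)c4cccc(C(F)(F)F)c4)c3)cc2-c2ccncc2)ccc1Cl` gives 1630 nM, which is the highest of the three numbers; its gap to compound 1 is within the scatter, while compound 3 lies beyond it.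

Compound 4 `COc1cc(-c2nn(-c3cccc(NC(=O)Nc4ccc(Cl)c(C(F)(F)F)c4)c3)cc2-c2ccncc2)ccc1Cl` has not yet been measured. It differs from compound 2 in one place: (4-chloro-3-(trifluoromethyl)phenyl)amino in place of 3-(trifluoromethyl)phenyl on a carbonyl carbon. For the measured compounds named here, no measured pair shows exactly this change. The nearest guide is the step of a 2.3-fold lower number from compound 1 to compound 3 (0.36 log units; beyond the scatter), where a trifluoromethyl added on the aromatic ring carried by the urea brought a modest gain. Going by the values given here, compound 4 carries a urea with a ring bearing both chlorine and trifluoromethyl, so a modest step in the same direction is expected, though the switch from amide to urea itself has no measured counterpart here.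

The estimate for compound 4 is therefore 800 nM, with a range from 350 nM to 1900 nM, which means an expected step of a 2.0-fold lower number from compound 2 to compound 4 (0.31 log units; beyond the scatter).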

Compound 4, concentration for 50% growth inhibition: 1080 nM
The estimate for compound 4 lay 1.4-fold (0.13 log units) below the measured number; measured number inside the range.
By their numbers in this assay, from the lowest: compounds 3, 4, 1 and 2 (each within the scatter of the next, the first and the last beyond it).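

In this assay, placing (4-chloro-3-(trifluoromethyl)phenyl)amino on this carbonyl carbon instead of 3-(trifluoromethyl)phenyl gives a 1.5-fold lower number from compound 2 to compound 4 (0.18 log units; within the scatter), so turning the amide into a urea and adding a chlorine at once brings no change that stands clear of the scatter. For the compounds shown here, the only earlier step, a trifluoromethyl added to the urea's ring in a 2.3-fold lower number from compound 1 to compound 3 (0.36 log units; beyond the scatter), did stand clear of it, so a change at this end of the molecule can matter, but this larger one did not show that here. No measurement shown here explains the difference between these two steps.

The compounds shown leave open how much of the new step belongs to the added amino nitrogen and how much to the chlorine. They also leave open what a nitrile or a carboxylic acid in place of that chlorine would give.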